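The source may report more compounds than this note shows. Statements on the series, on what has been measured and on what is new or still open speak of the compounds shown alone.

Working notes on the series. Compound 1 `O=C(NC1(C(=O)NO)CCC1)c1ccc(C#Cc2ccccc2)cc1` gives 5000 nM in a physicochemical assay for solubility; a lower number here means a less soluble compound, a higher number a more soluble compound; compound 2 `CC(NC(=O)c1ccc(C#Cc2ccccc2)cc1)C(=O)NO` gives 29000 nM; compound 3 `CC(C)(NC(=O)c1ccc(C#Cc2ccccc2)cc1)C(=O)NO` gives 182000 nM. Compound 3 stands highest of the three measured numbers, with a 6.3-fold higher number from compound 2 to compound 3 (0.80 log units; beyond the scatter) and a 36-fold higher number from compound 1 to compound 3 (1.56 log units; beyond the scatter). Compound 4 `O=C(N[C@H](CO)C(=O)NO)c1ccc(C#Cc2ccccc2)cc1` differs from compound 3 on the same amide-type nitrogen: a group of 7 heavy atoms (3 carbon, 1 nitrogen, 3 oxygen; no ring) in place of a group of 7 heavy atoms (4 carbon, 1 nitrogen, 2 oxygen; no ring), on an amide-type nitrogen. Within the data shown here, the steps that bear on this change are a 5.8-fold higher number from compound 1 to compound 2 (0.76 log units; beyond the scatter), a 36-fold higher number from compound 1 to compound 3 (1.56 log units; beyond the scatter) and a 6.3-fold higher number from compound 2 to compound 3 (0.80 log units; beyond the scatter), each a change of the group on that nitrogen and each beyond the scatter. The group that enters matches the leaving one in size but not in atoms, so direction is unsettled; the expected step in this assay is a 1.8-fold lower number from compound 3 to compound 4 (0.26 log units; within the scatter), not clearly beyond the scatter. Compound 4 is therefore estimated at 100000 nM, range 30000 nM to 400000 nM.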

Compound 4, solubility: 36000 nM
Beside the measured number, compound 4's estimate is 2.8-fold (0.44 log units) above it; the measured number falls inside the stated range.
By their numbers in this assay, from the lowest: compound 1; then compounds 2 and 4 (each within the scatter of the next); then compound 3.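

At this amide-type nitrogen in this assay, a group matching 1-(hydroxycarbamoyl)-1-methylethyl in size but not in atoms gives a 5.1-fold lower number from compound 3 to compound 4 (0.70 log units; beyond the scatter), so equal size does not carry over the number of compound 3. The other steps are a 1.2-fold higher number from compound 2 to compound 4 (0.09 log units; within the scatter), which leaves no readable difference, and a 7.2-fold higher number from compound 1 to compound 4 (0.86 log units; beyond the scatter), which keeps the gain over the cyclobutyl group. No measurement available here bears on the cause of these steps.

The compounds shown leave open how an amine or a carboxylic acid on this group would read in this assay. From the compounds shown here alone, the opposite configuration at the defined stereocentre of compound 4 also remains open.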